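Ester swap at the carbonyl oxygen: from cyclohexyl to isopentyl

This account rests on a few compounds, and the source may have more. Where it says the series, first, only, none or still open, it means among the compounds named here.

compound 1 `CCCCOC(=O)C(O)Cn1cnc2c(N)ncnc21`: 200 ug/mL
compound 2 `Nc1ncnc2c1ncn2CC(O)C(=O)OC1CCCCC1`: 100 ug/mL

In a functional assay on Vero cells (Chlorocebus sabaeus) for cytotoxicity (a higher number here means that more compound is tolerated, a lower number that less compound is tolerated), compound 1 `CCCCOC(=O)C(O)Cn1cnc2c(N)ncnc21` gives 200 ug/mL, and compound 2 `Nc1ncnc2c1ncn2CC(O)C(=O)OC1CCCCC1` gives 100 ug/mL. Compound 2 stands alongside compound 1, since the step of a 2.0-fold lower number from compound 1 to compound 2 (0.30 log units; within the scatter) puts the two numbers within the scatter of each other.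

Compound 3 `CC(C)CCOC(=O)C(O)Cn1cnc2c(N)ncnc21` differs from compound 2 in one place: isopentyl in place of cyclohexyl on an oxygen next to a carbonyl group. For the measured compounds named here, the one measured step that bears on this position is a 2.0-fold lower number from compound 1 to compound 2 (0.30 log units; within the scatter), which exchanged one group on the oxygen next to the carbonyl for another and stayed within the scatter. Going by the values given here, it is the sole guide, and it points to no movement beyond the scatter for a further exchange of this kind, with a ring leaving and a chain entering. For compound 3 the expected step is a 1.5-fold higher number from compound 2 to compound 3 (0.18 log units; within the scatter). Compound 3 is estimated at 150 ug/mL, with a range from 50 ug/mL to 400 ug/mL.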

Compound 3, minimum cytotoxic concentration: 400 ug/mL
Compound 3: the middle estimate sits 2.7-fold (0.43 log units) below what was measured; low and high end bracket the measured number.
By their numbers in this assay, from the lowest: compounds 2, 1 and 3 (each within the scatter of the next, the first and the last beyond it).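

In this assay, for the compounds shown here, the exchange of cyclohexyl for isopentyl on an oxygen next to a carbonyl group gives a 4.0-fold higher number from compound 2 to compound 3 (0.60 log units; beyond the scatter) and is the first step at this position to pass the scatter, so the group on this oxygen can move the read-out. Butyl does not separate from either neighbour: the added methyl on the chain gives a 2.0-fold higher number from compound 1 to compound 3 (0.30 log units; within the scatter) and leaves compound 1 within the scatter of compound 3, just as it lies within the scatter of compound 2, so only the two ends of the series stand apart. The data offer no explanation for the gap between cyclohexyl and isopentyl.

With a single ring among the compounds shown, they leave open whether the gap belongs to rings in general or to cyclohexyl alone. They also leave open how a longer chain, a phenyl ring or a free carboxylic acid in place of the ester would read.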